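The source may report more compounds than this note shows. Statements on the series, on what has been measured and on what is new or still open speak of the compounds shown alone.

Compound 1, `CCC(c1ccccc1)c1nc(-c2ccc(Cl)cc2)c(CC(=O)O)s1`: in an in vitro functional assay on HEK285-7 cells for antagonist activity at prostaglandin D2 receptor 2 (Homo sapiens), read by BRET and beta-arrestin recruitment (on this read-out lower numbers stand for stronger inhibition and higher numbers for weaker inhibition), compound 1 reaches only the limit of the assay, > 100000 nM.
Compound 2, `O=C(O)Cc1sc(C2COc3ccccc3O2)nc1-c1ccc(Cl)cc1`: in this assay compound 2 gives 2000 nM.
Compound 3, `O=C(O)Cc1sc(C(Cc2ccccc2)c2ccccc2)nc1-c1ccc(Cl)cc1`: in this assay compound 3 gives 510 nM.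

Among the two numbers, compound 3 stands lowest, with compound 2 as its nearest neighbour, while compound 1 adds only a limit (the limit of > 100000 nM in this assay, at which 1 of the 3 values shown sits). Compound 4, `O=C(O)Cc1sc(C(c2ccccc2)c2ccc(Cl)cc2)nc1-c1ccc(Cl)cc1`, differs from compound 3 in one place: 4-chlorophenyl in place of benzyl on a saturated chain carbon bound to two aromatic carbons. Going by the values given here, the single measured step at this chain carbon, an at least 190-fold lower number from compound 1 to compound 3 (2.29 log units; beyond the scatter), shows how strongly the group on that carbon can move the number, yet it exchanges methyl for phenyl and does not bear directly on replacing benzyl by 4-chlorophenyl. A modest step in either direction is expected for compound 4: a 1.3-fold lower number from compound 3 to compound 4 (0.11 log units; within the scatter). Compound 4 is therefore estimated at 400 nM in this assay, with a range from 100 nM to 2000 nM.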

Compound 4, half-maximal inhibitory concentration: 75 nM
For compound 4 the middle estimate is 5.3-fold (0.73 log units) above the measured one; measured number below the stated range.
By their numbers in this assay, from the lowest: compound 4; then compound 3; then compound 2. At a limit, above all of these: compound 1.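

Swapping benzyl for 4-chlorophenyl on this saturated chain carbon keeps the count of 7 heavy atoms and the one aromatic ring, yet in this assay it still gives a 6.8-fold lower number from compound 3 to compound 4 (0.83 log units; beyond the scatter), so the identity of the group matters, not only its size by that count. Ethyl and 4-chlorophenyl at this place are much further apart, an at least 1300-fold lower number from compound 1 to compound 4 (3.12 log units; beyond the scatter), though that step rests on a limit, not a number: the limit of > 100000 nM in this assay, at which 1 of the 4 values shown sits.

On these data alone, whether the chlorine or the loss of the benzyl chain carbon carries the gain stays open. So does what a plain phenyl, 4-fluorophenyl or 4-methoxyphenyl group would give here.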